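Changing One Aromatic Group on Compound 3

This account rests on a few compounds, and the source may have more. Where it says the series, first, only, none or still open, it means among the compounds named here.

In a functional assay on SW480 cells (Homo sapiens) for antiproliferative activity, read by sulforhodamine B assay, with a stated time of 48 h (a lower number here means a stronger inhibitor, a higher number a weaker inhibitor), compound 1 `COc1cccc(/C=C/C(=O)/C=C(O)/C=C/c2cccc(OC)c2OC)c1OC` gives 12100 nM and compound 2 `COc1ccc(OC)c(/C=C/C(=O)/C=C(O)/C=C/c2cc(OC)ccc2OC)c1` gives 15600 nM, two values within the usual scatter of each other. Compound 3 `COc1cc(OC)c(C=C(C(=O)/C=C/c2cccc(OC)c2OC)C(=O)/C=C/c2cccc(OC)c2OC)c(OC)c1` gives 840 nM, the lowest of the three numbers, and its gap to each of the other two lies beyond the scatter.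

The next compound to be tested, compound 4 `COc1ccc(C=C(C(=O)/C=C/c2cccc(OC)c2OC)C(=O)/C=C/c2cccc(OC)c2OC)cc1O`, carries 3-hydroxy-4-methoxyphenyl in place of 2,4,6-trimethoxyphenyl on a double-bonded chain carbon bound to a double-bonded chain carbon. Going by the values given here, no measured pair shows this swap or anything close to it, so the data cannot say directly how much it matters. Among the compounds with values here, the only firm anchor is compound 3 at 840 nM, and the expectation built on it is cautious. The expected change is a 1.8-fold higher number from compound 3 to compound 4 (0.25 log units; within the scatter), a small step toward a weaker inhibitor, though this is uncertain in size and direction. For compound 4 the estimated value is 1500 nM, with an expected range from 450 nM to 5000 nM.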

Compound 4, half-maximal inhibitory concentration: 320 nM
Compound 4: the middle estimate sits 4.7-fold (0.67 log units) above what was measured; the whole stated range lies above it.
By their numbers in this assay, from the lowest: compound 4; then compound 3; then compounds 1 and 2 (each within the scatter of the next).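

In this assay, exchanging the one aromatic group that differs gives a 2.6-fold lower number from compound 3 to compound 4 (0.42 log units; beyond the scatter), the first change in a single place among these compounds. This shows that the number responds to the aromatic group at this position, and that 2,4,6-trimethoxyphenyl is not required for a value in this range, even though the group that enters is smaller and brings a hydrogen-bond donor. Nothing available explains why the number fell.

This single step replaces the whole aromatic group, so it cannot separate the gain of the hydroxy group from the loss or rearrangement of the methoxy groups. As far as these compounds go, whether an amine or a carboxylic acid in place of that hydroxy group would keep the lower number also remains open.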